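This account rests on a few compounds, and the source may have more. Where it says the series, first, only, none or still open, it means among the compounds named here.

Measured so far in a functional assay on SMMC-7721 cells (Homo sapiens) for cytotoxicity, read by MTT assay, with a stated time of 72 h; a lower number here means a stronger inhibitor, a higher number a weaker inhibitor:
compound 1, `O=C(CSC(=S)N[C@H]1CCOC1=O)Nc1ccc(Cl)cc1`; compound 1 gives > 128000 nM, a limit of the assay.
compound 2, `O=C(CSC(=S)N[C@H]1CCOC1=O)Nc1ccccc1`; compound 2 gives > 128000 nM, a limit of the assay.

Compound 2 therefore stands at the limit of this assay, with no number attached; the limit of > 128000 nM in this assay, at which 2 of the 2 values shown sit, shows both values sitting there. The step that the two limits leave unreadable from compound 1 to compound 2, hydrogen in place of chloro on an aromatic carbon, cannot be read from two limits.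

Compound 3, `O=C(CSC(=S)N[C@H]1CCOC1=O)Nc1ccccc1Cl`, differs from compound 2 by chloro in place of hydrogen on an aromatic carbon. No readable measured step bears on this change. Compound 3 is expected to stay at the limit, so the step of a number no higher from compound 2 to compound 3 (the limit leaves the size open) is estimated as none beyond the scatter. Compound 3 is estimated at 128000 nM, within 50000 nM to 300000 nM.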

Compound 3, half-maximal inhibitory concentration: 49900 nM
Estimate against measurement, compound 3: 2.6-fold (0.41 log units) above; the measured number lies below the stated range.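

In this assay, for the compounds shown here, chloro in place of hydrogen ortho to a large group gives the first readable number, an at least 2.5-fold lower number from compound 2 to compound 3 (0.40 log units; beyond the scatter) with that single change. Moving the same atom also counts here: 2-chlorophenyl in place of 4-chlorophenyl gives an at least 2.5-fold lower number from compound 1 to compound 3 (0.40 log units; beyond the scatter) on the same shared core. Both sizes stay open-ended, as the other two compounds give no number: the limit of > 128000 nM in this assay, at which 2 of the 3 values shown sit.

Left open is whether bromo, methoxy or an amine ortho to a large group would follow chloro. Also open, going by these compounds, is how far the number would move with a second chloro on the six-membered aromatic ring.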